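A few compounds are considered here, and "the series" means these few. Any claim that something is new, unique, unknown or untested is made for them only; others in the source may bear on it.

Of the compounds shown here, three sharing one core have been measured so far. Compound 1 `Cn1ncc2cc(-c3cnc4[nH]ccc4c3N3CCC4(CCNC4=O)CC3)ccc21` gives 7 nM in an assay on cells for binding affinity to Cyclin-C/Cyclin-dependent kinase 19 (Homo sapiens), read by LanthaScreen; a lower number here means a stronger inhibitor, a higher number a weaker inhibitor. Compound 2 `O=C1NCCC12CCN(c1c(-c3ccc4scnc4c3)cnc3[nH]ccc13)CC2` gives 14 nM in this assay, and compound 3 `O=C1NCCC12CCN(c1c(-c3ccc4[nH]cnc4c3)cnc3[nH]ccc13)CC2` gives 17 nM in this assay. Compound 3 carries the highest of the three numbers: its gap to compound 2 lies within the scatter, while the step of a 2.4-fold higher number from compound 1 to compound 3 (0.39 log units; beyond the scatter) is the only one that reaches beyond it. The step of a 2.0-fold higher number from compound 1 to compound 2 (0.30 log units; within the scatter) and the step of a 1.2-fold higher number from compound 2 to compound 3 (0.08 log units; within the scatter) both stay inside the scatter.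

Compound 4 `O=C1NCCC12CCN(c1c(-c3ccn4ccnc4c3)cnc3[nH]ccc13)CC2` is not yet measured. It differs from compound 3 by a group of 9 heavy atoms (7 carbon, 2 nitrogen; one five-membered aromatic ring with 2 hetero atoms, one six-membered aromatic ring with 1 hetero atom) in place of a group of 9 heavy atoms (7 carbon, 2 nitrogen; one five-membered aromatic ring with 2 hetero atoms, one six-membered aromatic ring of carbon only), on an aromatic carbon. All three measured steps concern exchanges of this same aromatic group, and none of them moved the number by more than the modest step from compound 1 to compound 3. The exchange from compound 3 to compound 4 is therefore expected to produce at most a modest step in this assay, with the direction uncertain, since the group that enters has no donor where the earlier groups differed in that respect. The step of a 1.2-fold higher number from compound 3 to compound 4 (0.07 log units; within the scatter) is the expected outcome. Compound 4 is estimated to reach 20 nM in this assay, with a range from 8 nM to 50 nM.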

Compound 4, half-maximal inhibitory concentration: 68 nM
Beside the measured number, compound 4's estimate is 3.4-fold (0.53 log units) below it; the whole stated range lies below it.
By their numbers in this assay, from the lowest: compounds 1, 2 and 3 (each within the scatter of the next, the first and the last beyond it); then compound 4.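

For the compounds shown here, at this position, on an aromatic carbon ortho to a large group, the earlier exchanges of one fused group for another stayed close together in this assay, but this change gives the first clear loss among groups of equal size: a 4.0-fold higher number from compound 3 to compound 4 (0.60 log units; beyond the scatter), although the heavy atoms are the same and only joined differently. The group that enters also stands apart from the other two groups, with a 4.9-fold higher number from compound 2 to compound 4 (0.69 log units; beyond the scatter) and a 9.7-fold higher number from compound 1 to compound 4 (0.99 log units; beyond the scatter), so the position does not accept every fused aromatic group alike. Of the four groups, this is the only one with a hetero atom in its six-membered aromatic ring, and compound 4 alone sits beyond the scatter of every other compound.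

Nothing available explains why the number rises. The compounds shown leave open whether the rise follows the ring nitrogen in the six-membered ring or the loss of the hydrogen-bond donor of the 1H-benzimidazol-5-yl group, a question that a 1-methyl-1H-benzimidazol-5-yl group on the same core could help to separate.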